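A few compounds are considered here, and "the series" means these few. Any claim that something is new, unique, unknown or untested is made for them only; others in the source may bear on it.

Compound 1 `CCCC/C=C\CCCCCCCCCCC[C@H](O)Cc1cc(O)ccc1O` and compound 2 `CCCC/C=C\CCCCCCCCC[C@H](O)Cc1cc(O)ccc1O` share the same core and differ only in the side chain. In a functional assay on A673 cells (Homo sapiens) for inhibition, read by sulforhodamine B assay, with a stated time of 48 h (on this read-out lower numbers stand for stronger inhibition of growth and higher numbers for weaker inhibition of growth), compound 1 gives 320 nM, and compound 2 gives 160 nM. The change between them is hex-1-en-1-yl in place of oct-3-en-1-yl on a saturated chain carbon, ten or more bonds along the chain from an oxygen on a saturated carbon, and it made a step of a 2.0-fold lower number from compound 1 to compound 2 (0.30 log units; within the scatter).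

Compound 3 `CCCC/C=C\CCCCCCCCCCC[C@H](O)C[C@]1(O)CC(=O)C=C[C@H]1O` carries the longer chain of compound 1 on a different core; how the two cores differ is a group of 9 heavy atoms (6 carbon, 3 oxygen; one six-membered non-aromatic ring of carbon only) in place of a group of 8 heavy atoms (6 carbon, 2 oxygen; one six-membered aromatic ring of carbon only), on a saturated chain carbon, two bonds along the chain from an oxygen on a saturated carbon. In this assay compound 3 gives 580 nM, a step of a 1.8-fold higher number from compound 1 to compound 3 (0.26 log units; within the scatter).

Compound 4 `CCCC/C=C\CCCCCCCCC[C@H](O)C[C@]1(O)CC(=O)C=C[C@H]1O` has not yet been measured in this assay. It stands to compound 3 as compound 2 stands to compound 1: the change is hex-1-en-1-yl in place of oct-3-en-1-yl on a saturated chain carbon, ten or more bonds along the chain from an oxygen on a saturated carbon, the same change as before at the same place. This change has been seen once among the compounds described here, in the step of a 2.0-fold lower number from compound 1 to compound 2 (0.30 log units; within the scatter). Because that step a 2.0-fold lower number from compound 1 to compound 2 (0.30 log units; within the scatter) was small, a step of similar size, a 2.0-fold lower number from compound 3 to compound 4 (0.30 log units; within the scatter), is expected here. Compound 4 is therefore estimated at 290 nM, with a range expected from 140 nM to 600 nM.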

Compound 4, concentration for 50% growth inhibition: 650 nM
Compound 4: middle estimate off by 2.2-fold (0.35 log units), on the low side; measured number above the stated range.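

On the core of compound 3, hex-1-en-1-yl in place of oct-3-en-1-yl gives a 1.1-fold higher number from compound 3 to compound 4 (0.05 log units; within the scatter), while exchanging the core with the shorter chain in place gives a 4.1-fold higher number from compound 2 to compound 4 (0.61 log units; beyond the scatter). In this assay, the chain change does not differ measurably between the two cores, so the small step seen on the first core is compatible with the one on the second: the same change on two cores in this assay, a 2.0-fold lower number (0.30 log units; within the scatter) from compound 1 to compound 2 and a 1.1-fold higher number (0.05 log units; within the scatter) from compound 3 to compound 4, 2.2-fold (0.35 log units) apart, within the scatter of two such steps The core change likewise does not differ measurably between the two chains, although with a single pair for each comparison this shows neither that the steps are truly the same nor that they depend on the partner group: the same change on two cores in this assay, a 1.8-fold higher number (0.26 log units; within the scatter) from compound 1 to compound 3 and a 4.1-fold higher number (0.61 log units; beyond the scatter) from compound 2 to compound 4, 2.2-fold (0.35 log units) apart, within the scatter of two such steps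

The compounds shown cover only these two side chains and these two cores, which leaves open how far the steps would hold outside this small set. On these data alone, whether a longer chain, a fully saturated chain or a chain bearing an amine or a carboxylic acid would follow the same pattern on both cores remains open.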